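Swapping a heptyl chain for a fluorophenyl ring

The compounds below may be only part of what the source reports. "The series", "measured", "known", "first", "only" and "open" are said of these compounds alone.

Of the compounds shown here, three sharing one core have been tested in an ADME assay on PANC-1 cells (Homo sapiens) for cytotoxicity, read by sulforhodamine B assay, with a stated time of 48 h, tested at 10 uM; on this read-out lower numbers stand for less inhibition and higher numbers for more inhibition at the one concentration tested (going by the name of the read-out). Compound 1 `CCCCCCCc1cn(C(c2ccccc2)c2cc3cc(Br)ccc3nc2OC)nn1` gives 16.6% in this assay. Compound 2 `COc1nc2ccc(Br)cc2cc1C(c1ccccc1)n1cc(-c2ccc(OC(F)(F)F)cc2)nn1` gives 11.7%, and compound 3 `COc1nc2ccc(Br)cc2cc1C(c1ccccc1)n1cc(CO)nn1` gives 15%. Numerically compound 1 stands at the top of these three, but the step of a number 4.9 percentage points lower from compound 1 to compound 2 (within the scatter) and the step of a number 1.6 percentage points lower from compound 1 to compound 3 (within the scatter) are both within the scatter, so the three compounds cannot be told apart on these numbers.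

Compound 4 `COc1nc2ccc(Br)cc2cc1C(c1ccccc1)n1cc(-c2ccc(F)cc2)nn1` has not yet been measured. It differs from compound 1 in one place: 4-fluorophenyl in place of heptyl on an aromatic carbon. For the measured compounds named here, the measured step that bears most directly on this change is the one from compound 1 to compound 2, where a six-membered aromatic ring also replaced the heptyl chain, and that step, a number 4.9 percentage points lower from compound 1 to compound 2 (within the scatter), was within the scatter. The step of a number 3.3 percentage points higher from compound 2 to compound 3 (within the scatter) likewise stayed within the scatter. On this basis no change beyond the scatter is expected in this assay, and the estimated step is a number 3.6 percentage points lower from compound 1 to compound 4 (within the scatter).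

Compound 4 is therefore expected to give about 13% in this assay, with a range from 4% to 22%.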

Compound 4, a percentage reported as inhibition, at one concentration (the size of the read-out at that concentration, not a potency): 14.9%
For compound 4 the middle estimate is 1.9 percentage points below the measured one; the measured number falls inside the stated range.
By their numbers in this assay, from the lowest: compounds 2, 4, 3 and 1 (each within the scatter of the next).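

Placing 4-fluorophenyl on this aromatic carbon of the five-membered ring swaps an open chain for a six-membered aromatic ring of the same heavy-atom count, and in this assay this gives a number 1.7 percentage points lower from compound 1 to compound 4 (within the scatter) with no change that can be told from the scatter. The two other comparisons, a number 0.1 percentage points lower from compound 3 to compound 4 (within the scatter) and a number 3.2 percentage points higher from compound 2 to compound 4 (within the scatter), agree with this, so heptyl, hydroxymethyl, 4-fluorophenyl and 4-(trifluoromethoxy)phenyl cannot be separated here, and on the aryl ring fluoro and trifluoromethoxy cannot be separated either. No supporting measurement is available to explain why these groups give such similar numbers.

These four compounds leave open whether any group at this position can move the number in this assay beyond the scatter, for example a carboxylic acid, a primary amine or an alkyl chain longer than heptyl. They also leave open whether these groups would still be indistinguishable at other concentrations, since each compound has a reading at only one.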